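A few compounds are considered here, and "the series" means these few. Any claim that something is new, unique, unknown or untested is made for them only; others in the source may bear on it.

Measured so far:
- compound 1 `CC1CCCN(c2nc(Cc3c(F)cccc3F)cc(=O)[nH]2)C1`: > 78000 nM
- compound 2 `O=c1cc(Cc2c(F)cccc2F)nc(-n2cccc2)[nH]1`: > 87000 nM
- compound 3 `Cc1c(Cc2c(F)cccc2F)nc(N(C)C(C)C)[nH]c1=O`: 79000 nM

In an ADME assay on MT4 cells (Homo sapiens) for cytotoxicity, read by MTT assay, with a stated time of 4 days (on this read-out higher numbers stand for lower toxicity in this test and lower numbers for higher toxicity in this test), compound 1 reaches only a limit of the assay, > 78000 nM, which is the limit of > 78000 nM in this assay, at which 1 of the 3 values shown sits. Compound 2 likewise reaches a limit, > 87000 nM, which is the limit of > 87000 nM in this assay, at which 1 of the 3 values shown sits. The step that the two limits leave unreadable from compound 1 to compound 2 therefore cannot be read. Among the compounds with values here, compound 3 gives the only true number of the three, and that number sits close to where the two limits fall. Compound 4 `Cc1c(Cc2c(F)cccc2F)nc(N2CCCCCC2)[nH]c1=O` differs from compound 3 by azepan-1-yl in place of isopropyl(methyl)amino on an aromatic carbon. Within the data shown here, no measured step covers this change, and the single measured step is unreadable; nothing here points to any direction. Compound 4 is expected to show a step of a 1.0-fold higher number from compound 3 to compound 4 (0.01 log units; within the scatter) from compound 3. Compound 4 is estimated at 80000 nM, with a range from 40000 nM to 160000 nM.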

Compound 4, half-maximal cytotoxic concentration: > 75000 nM
Compound 4: no number, only a limit (the forecaster's own chance of this, stated with the estimate: 50%); the middle value is on the limit's open side.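

Compound 4 reaches only a limit of the assay, > 75000 nM, so the step from compound 3 to compound 4 cannot be read. The compounds shown leave open whether changing this group on the shared core shifts the read-out at all.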